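Amino to dimethylamino on the shared core

This account rests on a few compounds, and the source may have more. Where it says the series, first, only, none or still open, it means among the compounds named here.

Compound 1 `Cc1c(C)c2c(c(C)c1N)CC(C)(C)O2`: 760 nM
Compound 2 `Cc1c(C)c2c(c(N)c1N)CC(C)(C)O2`: 300 nM

In a functional assay (microsomes, liver) with Rattus norvegicus as the target (a lower number here means a stronger inhibitor, a higher number a weaker inhibitor), compound 2 holds the lower of the two numbers, 300 nM. Compound 3 `Cc1c(C)c2c(c(N(C)C)c1N)CC(C)(C)O2` differs from compound 2 by dimethylamino in place of amino on an aromatic carbon. For the measured compounds named here, the one measured step, a 2.5-fold lower number from compound 1 to compound 2 (0.40 log units; beyond the scatter), is modest and introduced the amino group at this carbon. Going by the values given here, no measured step covers a change to dimethylamino, so the direction remains open, and no step beyond the scatter is expected. The estimated change is a 1.2-fold higher number from compound 2 to compound 3 (0.07 log units; within the scatter). For compound 3 the expected value is 350 nM, with an estimated range of 120 nM to 1000 nM.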

Compound 3, half-maximal inhibitory concentration: 550 nM
Compound 3: the middle estimate sits 1.6-fold (0.20 log units) below what was measured; the range from low to high includes it.
By their numbers in this assay, from the lowest: compounds 2, 3 and 1 (each within the scatter of the next, the first and the last beyond it).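

In this assay dimethylamino at this aromatic carbon gives a 1.8-fold higher number from compound 2 to compound 3 (0.26 log units; within the scatter) and, set against methyl at the same carbon, a 1.4-fold lower number from compound 1 to compound 3 (0.14 log units; within the scatter) as well. Compound 3 therefore cannot be separated from either neighbour, although compound 1 and compound 2 lie beyond the scatter of each other, so this change does not show whether the gain seen with amino is kept or lost. Nothing available bears on the reason for these numbers.

Going by these compounds, whether methylamino, which sits between the two amines in size, or an acetamide at this carbon would separate from compound 2 remains open.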